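Swapping a Dithiane Ring for an Acetoxy Group

The source may report more compounds than this note shows. Statements on the series, on what has been measured and on what is new or still open speak of the compounds shown alone.

Compound 1 `CC(=O)O[C@@H]1OC(=O)[C@](C)(C(C)=O)[C@@H]1C` gives 4000 nM in a functional assay on B16 cells (Mus musculus) for cytotoxicity, read by MTT assay; on this read-out higher numbers stand for weaker inhibition and lower numbers for stronger inhibition. Compound 2 `CC(=O)O[C@@H]1OC(=O)[C@](Cc2ccccc2)(C(C)=O)[C@@H]1C` gives 41000 nM in this assay. Compound 3 `CC(=O)O[C@@H]1OC(=O)[C@@](C(C)=O)(C2SCCCS2)[C@@H]1C` reaches only a limit of this assay, > 50000 nM. Compound 3 therefore sits at that limit (the limit of > 50000 nM in this assay, at which 1 of the 3 values shown sits), set apart from compound 1 by an at least 12-fold higher number from compound 1 to compound 3 (1.09 log units; beyond the scatter), whereas an at least 1.2-fold higher number from compound 2 to compound 3 (0.08 log units; that floor lies within the scatter) does not separate it from compound 2.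

Compound 4 `CC(=O)O[C@@H]1OC(=O)[C@](OC(C)=O)(C(C)=O)[C@@H]1C` carries a group of 4 heavy atoms (2 carbon, 2 oxygen; no ring) in place of a group of 6 heavy atoms (4 carbon, 2 sulfur; one six-membered non-aromatic ring with 2 hetero atoms), on a saturated ring carbon. The step of an at least 12-fold higher number from compound 1 to compound 3 (1.09 log units; beyond the scatter) shows how much the six-membered ring of 4 carbon and 2 sulfur atoms cost at this ring carbon; taking it away for the four-atom acetoxy group is expected to bring the number back down, an at least 3.3-fold lower number from compound 3 to compound 4 (0.52 log units; beyond the scatter). Compound 4 is thus estimated at about 15000 nM, between 3000 nM and 60000 nM.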

Compound 4, half-maximal inhibitory concentration: > 50000 nM
Compound 4: no number, only a limit; the forecaster's own chance of this, stated with the estimate: 25%; middle value at least 3.3-fold (0.52 log units) from the limit.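

Compound 4 joins compound 3 at a limit of this assay, not at a number: the limit of > 50000 nM in this assay, at which 2 of the 4 values shown sit. So removing the sulfur-bearing ring yields no readable number at this ring carbon, and acetoxy in place of methyl gives an at least 12-fold higher number from compound 1 to compound 4 (1.09 log units; beyond the scatter). Acetoxy in place of benzyl gives an at least 1.2-fold higher number from compound 2 to compound 4 (0.08 log units; that floor lies within the scatter), and the steps between the two limits cannot be read.

Among the compounds shown, only methyl at this ring carbon gives a value near that of compound 1. As far as these compounds go, whether a hydroxyl group, an amine or an ethyl chain there would keep a readable number remains open.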